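Cytotoxicity of Four Related Compounds on Canine Kidney Cells

The source may report more compounds than this note shows. Statements on the series, on what has been measured and on what is new or still open speak of the compounds shown alone.

Compound 1 `C=CC(C)(C)c1[nH]c2ccc(C[C@H](O)C(C)(C)OC)cc2c1/C=c1\[nH]c(=O)c(=C)[nH]c1=O` and compound 2 `C=CC(C)(C)c1[nH]c2c(C[C@H](O)C(C)(C)OC)cccc2c1/C=C1\NC(=O)[C@H](C)NC1=O` have cores that differ, and that difference is not broken down here. In an ADME assay on MDCK cells (Canis lupus familiaris) for cytotoxicity, read by CellTiter-Glo, with a stated time of 40 h (a higher number here means that more compound is tolerated, a lower number that less compound is tolerated), compound 1 reaches only the limit of > 200000 nM. Compound 2 likewise gives only the limit of > 200000 nM in this assay. Compound 3 `C=CC(C)(C)c1[nH]c2ccccc2c1/C=C1\NC(=O)[C@H](C)NC1=O` arises from compound 2 by hydrogen in place of 2-hydroxy-3-methoxy-3-methylbutyl on an aromatic carbon. Compound 3 also stops at the limit of > 200000 nM in this assay. The step that the two limits leave unreadable from compound 2 to compound 3 cannot be sized, because of the limit of > 200000 nM in this assay, at which 3 of the 3 values shown sit. Compound 4 `C=CC(C)(C)c1[nH]c2ccccc2c1/C=c1\[nH]c(=O)c(=C)[nH]c1=O` arises from compound 1 by the same kind of change, (hydrogen in place of 2-hydroxy-3-methoxy-3-methylbutyl on an aromatic carbon); around the place, the group leaving compound 2 sits ortho to a fused ring and meta to a fused ring, whereas the group leaving compound 1 sits meta to a fused ring and para to a fused ring. The step that the limit leaves unreadable from compound 1 to compound 4 is what is expected. This expectation rests on compound 1 sitting at its limit of > 200000 nM and on (the limit of > 200000 nM in this assay, at which 3 of the 3 values shown sit). Compound 4 is estimated at 300000 nM in this assay.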

Compound 4, half-maximal cytotoxic concentration: > 200000 nM
Compound 4 was reported as a limit; the forecaster's own chance of this, stated with the estimate: 85%; the middle value is on the limit's open side.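

Compound 1 and compound 4 both stop at a limit, so no step between them can be read: the limit of > 200000 nM in this assay, at which 4 of the 4 values shown sit.

The compounds shown leave open where the half-maximal cytotoxic concentration of each truly lies, and whether removing 2-hydroxy-3-methoxy-3-methylbutyl changes it on either core.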